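The compounds below may be only part of what the source reports. "The series", "measured", "known", "first", "only" and "open" are said of these compounds alone.

The set rests on a shared core. Compound 1 `CC1=CC[C@H]2[C@@H]1CC=C(C)[C@@H](CC[C@H]1[C@]3(C)CC[C@H](OC(=O)CCC(=O)O)C(C)(C)O[C@H]3CC[C@@]1(C)O)C2(C)C` opens it. In a functional assay on MCF7 cells (Homo sapiens) for antiproliferative activity, read by MTT assay, with a stated time of 72 h (a higher number here means a weaker inhibitor, a lower number a stronger inhibitor), compound 1 gives > 50000 nM, which is a limit of the assay rather than a measured number. Compound 2 `CC1=CC[C@H]2[C@H](CC[C@]2(C)O)C(C)(C)[C@@H]1CC[C@H]1[C@]2(C)CC[C@H](OCc3ccccc3)C(C)(C)O[C@H]2CC[C@@]1(C)O` is the second compound. In this assay compound 2 gives > 50000 nM, again a limit of the assay and not a number. Where compound 2 stands is therefore set by the limit of > 50000 nM in this assay, at which 2 of the 2 values shown sit, and no single-change step between measured compounds is available, so the two values show only that neither compound reached a measurable half-maximal inhibitory concentration. Compound 3 `CC1=CC[C@H]2[C@H](CC[C@]2(C)O)C(C)(C)[C@@H]1CC[C@H]1[C@]2(C)CC[C@H](OC(=O)c3ccccc3F)C(C)(C)O[C@H]2CC[C@@]1(C)O` differs from compound 2 by (2-fluorophenyl)carbonyl in place of benzyl on an oxygen on a saturated carbon. The step from compound 2 to compound 3 is expected to be none beyond the scatter, a step that the limit leaves unreadable from compound 2 to compound 3. Compound 3 is expected to give 60000 nM in this assay, within 15000 nM to 200000 nM, most likely reported only as a limit.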

Compound 3, half-maximal inhibitory concentration: 11300 nM
Beside the measured number, compound 3's estimate is 5.3-fold (0.73 log units) above it, and the stated range ends above it.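

In this assay, the substituent on this oxygen on a saturated carbon proves able to change the read-out: (2-fluorophenyl)carbonyl in place of benzyl gives an at least 4.4-fold lower number from compound 2 to compound 3 (0.64 log units; beyond the scatter). Among the compounds shown here, compound 3 is the first compound in the set with a measured half-maximal inhibitory concentration rather than a limit, so this position is not silent in the way the earlier values left it appearing. The true size of the step stays unknown because compound 2 is recorded only as a limit of the assay: the limit of > 50000 nM in this assay, at which 2 of the 3 values shown sit.

The change brings in a carbonyl and a fluorine together, so the compounds shown do not tell which of them carries the step. A plain benzoyl group or a 2-fluorobenzyl group on this oxygen would separate the two.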